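A few compounds are considered here, and "the series" means these few. Any claim that something is new, unique, unknown or untested is made for them only; others in the source may bear on it.

Working notes on a set of diamino-substituted compounds sharing one core, examined in a functional assay on UACC-62 cells (Homo sapiens) for inhibition, read by sulforhodamine B assay, with a stated time of 48 h; on this read-out lower numbers stand for stronger inhibition of growth and higher numbers for weaker inhibition of growth.

Three members have been measured. Compound 1 `Nc1cc(N)c2nc(-c3ccccc3)c(Oc3ccc(Cl)c(Cl)c3)nc2c1` gives 47900 nM in this assay. Compound 2 `Nc1cc(N)c2nc(-c3ccccc3)c(NCc3ccc(Cl)c(Cl)c3)nc2c1` gives 30900 nM, and compound 3 `CCOC(=O)[C@H](CCC(=O)O)NC(=O)c1ccc(Sc2nc3cc(N)cc(N)c3nc2-c2ccccc2)cc1` gives 38900 nM. Compound 1 holds the highest of the three numbers, but its gap to compound 3 and its gap to compound 2 both lie within the usual scatter, so the three measured compounds cannot be ordered against one another on these data; all sit in the same region of weak growth inhibition.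

The next compound, compound 4 `Nc1cc(N)c2nc(-c3ccccc3)c(Oc3ccc(F)cc3)nc2c1`, is a single-change relative of compound 1: 4-fluorophenyl in place of 3,4-dichlorophenyl on an oxygen on an aromatic ring. Going by the values given here, no pair of measured compounds differing in one place is available, so there is no measured step to lean on for this change.

Given that compound 1 gives 47900 nM and that compounds 2 and 3 with other groups in related positions lie within the scatter of it, the expectation is that compound 4 stays in the same weak region, with a step from compound 1 to compound 4 of a 1.1-fold higher number from compound 1 to compound 4 (0.06 log units; within the scatter) expected, i.e. none beyond the scatter or a slight rise. Compound 4 is accordingly estimated at 55000 nM, expected to fall between 25000 nM and 120000 nM.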

Compound 4, concentration for total growth inhibition: 33100 nM
Estimate against measurement, compound 4: 1.7-fold (0.22 log units) above; the measured number falls inside the stated range.
By their numbers in this assay, from the lowest: compounds 2, 4, 3 and 1 (each within the scatter of the next).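

In this assay, going by these compounds alone, the only single-place step available for this series, a 1.4-fold lower number from compound 1 to compound 4 (0.16 log units; within the scatter), replaces 3,4-dichlorophenyl with 4-fluorophenyl on an oxygen on an aromatic ring. Within the data shown here, this gives the first direct reading at this position, and it shows that this exchange, which removes both chlorines and introduces one fluorine, produces no change that can be separated from the usual scatter. No supporting data on any property of these two groups accompany the step, so the result stands without an explanation.

The compounds shown leave open whether this position responds to anything other than a halogen-bearing phenyl, since a single step between two such groups cannot show how far the insensitivity extends. A phenyl carrying an amine or a carboxylic acid, or a longer chain in place of the aromatic ring on the oxygen, would show whether the growth-inhibition number in this assay can move beyond the scatter through a change at this position.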